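A few compounds are considered here, and "the series" means these few. Any claim that something is new, unique, unknown or untested is made for them only; others in the source may bear on it.

Measured in a functional assay on the whole organism (artery, strain albino) with Rattus norvegicus as the target, with a stated time of 180 min, at a dose of 10 mg/kg by the oral route; a higher number here means more inhibition at the dose given (going by the name of the read-out), a lower number less inhibition:

compound 1, `CC1=C(C(=O)Nc2ccc([N+](=O)[O-])cc2)C(c2cccc([N+](=O)[O-])c2)N=C(SCc2ccccc2Cl)N1`: 9.3%
compound 2, `CC1=C(C(=O)Nc2ccc([N+](=O)[O-])cc2)C(c2cccc([N+](=O)[O-])c2)N=C(SCc2cccc(Cl)c2)N1`: 14.9%
compound 3, `CC1=C(C(=O)Nc2ccc([N+](=O)[O-])cc2)C(c2cccc([N+](=O)[O-])c2)N=C(SCc2ccc(Cl)cc2)N1`: 14.9%

Compound 3 sits level with compound 2: no change at the digits printed from compound 2 to compound 3 (within the scatter). Against compound 1 the difference is a number 5.6 percentage points higher from compound 1 to compound 3 (within the scatter), and the parallel step a number 5.6 percentage points higher from compound 1 to compound 2 (within the scatter) is of the same size, so all three numbers lie within the scatter of one another and no ordering among them can be read from this assay.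

Compound 4, `CC1=C(C(=O)Nc2ccc([N+](=O)[O-])cc2)C(c2cccc([N+](=O)[O-])c2)N=C(SCc2ccc(F)cc2)N1`, differs from compound 3 by fluoro in place of chloro on an aromatic carbon. Within the data shown here, none of the measured steps changes the halogen itself; each of them moves a chloro from one position of the benzyl ring to another, and each stays within the scatter. The step from compound 3 to compound 4 is therefore not covered by any measured pair, but the closest analogy is a series in which small changes on this ring leave the read-out essentially flat. The expected step is a number 1.9 percentage points lower from compound 3 to compound 4 (within the scatter), that is, nothing beyond the scatter. For compound 4 the estimate in this assay is 13%, with a range from 3% to 24%.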

Compound 4, a percentage reported as inhibition, in the whole organism at one dose (the size of the read-out at that dose, not a potency): 17.5%
The estimate for compound 4 lay 4.5 percentage points below the measured number; measured number inside the range.
By their numbers in this assay, from the lowest: compounds 1, 2, 3 and 4 (each within the scatter of the next).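

In this assay, fluoro in place of chloro on an aromatic carbon, para to a large group, is the only step shown that changes the halogen itself, and it reads a number 2.6 percentage points higher from compound 3 to compound 4 (within the scatter) with no shift beyond the scatter. The two steps that also alter where the halogen sits, a number 2.6 percentage points higher from compound 2 to compound 4 (within the scatter) and a number 8.2 percentage points higher from compound 1 to compound 4 (within the scatter), stay within the scatter as well, so neither the identity of the halogen nor its place separates these four compounds at this dose. Nothing measured here accounts for this flat picture.

Open, as far as these compounds go, is whether a group other than a halogen on this carbon, such as an amine, a carboxylic acid or a methoxy group, would give a step beyond the scatter. Also open, from the compounds shown here alone, is whether a longer chain in place of the benzyl group would do so.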